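The compounds below may be only part of what the source reports. "The series", "measured", "known", "first", "only" and "open" are said of these compounds alone.

Working notes on the series, read in a functional assay on SW 1116 cells (Homo sapiens) for antiproliferative activity, read by MTT assay, with a stated time of 24 h; a higher number here means a weaker inhibitor, a lower number a stronger inhibitor. Compound 1 (`O=[N+]([O-])c1ccc(CSc2nnc(-c3ccc4c(c3)OCCO4)n2-c2ccccc2)cc1`) gives 13800 nM, and compound 2 (`Brc1cccc(CSc2nnc(-c3ccc4c(c3)OCCO4)n2-c2ccccc2)c1`) gives 26200 nM. Among the compounds with values here, compound 2 therefore stands level with compound 1 on the only two numbers available, as the one measured step reads a 1.9-fold higher number from compound 1 to compound 2 (0.28 log units; within the scatter).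

The next structure is compound 3 (`Brc1ccc(CSc2nnc(-c3ccc4c(c3)OCCO4)n2-c2ccccc2)cc1`), which keeps the shared core: 4-bromophenyl in place of 3-bromophenyl on a saturated chain carbon bound to a sulfur. Compounds 2 and 3 have the same atoms, joined differently, and the change falls on a saturated chain carbon bound to a sulfur.

Within the data shown here, only the step between compounds 1 and 2 bears on this, since it is the one measured change at the same place. It swapped 4-nitrophenyl for 3-bromophenyl and stayed within the scatter, at a 1.9-fold higher number from compound 1 to compound 2 (0.28 log units; within the scatter). Among the measured compounds shown here, no pair differing only between 3-bromophenyl and 4-bromophenyl has been measured. On that thin evidence, no step beyond the scatter is expected in this assay, and no firm direction can be given.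

The estimated step is a 1.3-fold lower number from compound 2 to compound 3 (0.12 log units; within the scatter). For compound 3 the expected value is 20000 nM, with an estimated range of 9000 nM to 45000 nM.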

Compound 3, half-maximal inhibitory concentration: 5810 nM
Compound 3: middle estimate off by 3.4-fold (0.54 log units), on the high side; the whole stated range lies above it.
By their numbers in this assay, from the lowest: compound 3; then compounds 1 and 2 (each within the scatter of the next).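

In this assay, the position on a saturated chain carbon bound to a sulfur proves sensitive to where the bromine sits on the ring: 4-bromophenyl in place of 3-bromophenyl gives a 4.5-fold lower number from compound 2 to compound 3 (0.65 log units; beyond the scatter), a modest step with no change in atoms, which the earlier step within the scatter gave no sign of. Bromo in place of nitro on an aromatic carbon gives a 2.4-fold lower number from compound 1 to compound 3 (0.38 log units; beyond the scatter), also modest, so the 4-substituted pair separates as well, and compound 3 is the strongest inhibitor of the three. Nothing available accounts for either step.

The compounds shown leave open whether the gain belongs to bromine itself or to any group at that ring position, which 4-chlorophenyl, 4-methoxyphenyl or plain phenyl on the same chain carbon would help to separate. They also leave open whether a 3-nitrophenyl group would trail 4-nitrophenyl as 3-bromophenyl trails 4-bromophenyl, since the isomer effect so far rests on a single pair.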